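A Methyl Group and Solubility in Two Related Series

The source may hold more compounds than are shown below. What is called first, only, known or untested is meant among the compounds shown, and "the series" means these compounds.

Of the compounds shown here, three have been measured in a physicochemical assay for solubility, read by spectrophotometry, in phosphate buffer, measured as kinetic solubility, with a stated time of 18 h, at pH 7.4; a higher number here means a more soluble compound, a lower number a less soluble compound. Compound 1 `O=C(Nc1ccc(O)c(-c2nc3ccccc3s2)c1)c1cc([N+](=O)[O-])ccc1Cl` gives 23 nM. Compound 2 `Cc1cc(NC(=O)c2cc([N+](=O)[O-])ccc2Cl)cc(-c2nc3ccccc3s2)c1O` gives 430 nM. Compound 3 `O=C(Nc1cccc(-c2nc3ccccc3o2)c1)c1cc([N+](=O)[O-])ccc1Cl` gives 470 nM.

Compound 2 differs from compound 1 by one change: methyl in place of hydrogen on an aromatic carbon. This change produced a 19-fold higher number from compound 1 to compound 2 (1.27 log units; beyond the scatter), a step that is beyond the scatter of repeated measurements. Compound 3 has the highest number of the three, and its value sits close to that of compound 2, within the usual scatter, so no order can be claimed between them. The difference between the core of compound 3 and the core of compound 1 is not broken down here.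

Compound 4 `Cc1ccc(-c2nc3ccccc3o2)cc1NC(=O)c1cc([N+](=O)[O-])ccc1Cl` has not yet been measured. It differs from compound 3 by methyl in place of hydrogen on an aromatic carbon. Among the measured compounds shown here, this is the same kind of change as the one from compound 1 to compound 2, but the surroundings differ. In compound 2 the methyl sits ortho to a hydroxy group, meta to a 1,3-benzothiazol-2-yl group and meta to a large group; in compound 4 it sits ortho to a large group and para to a 1,3-benzoxazol-2-yl group. For the measured compounds named here, because the only measured example, a 19-fold higher number from compound 1 to compound 2 (1.27 log units; beyond the scatter), comes from a different setting, the expectation for compound 4 is held loosely. The expected step is a 1.3-fold higher number from compound 3 to compound 4 (0.11 log units; within the scatter), smaller than the measured one. Compound 4 is therefore expected to give 600 nM, with an estimated range from 150 nM to 2500 nM.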

Compound 4, solubility: 310 nM
Estimate against measurement, compound 4: 1.9-fold (0.29 log units) above; the range from low to high includes it.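

In this assay, among the compounds shown here, the methyl swap on the core of compound 3 gives a 1.5-fold lower number from compound 3 to compound 4 (0.18 log units; within the scatter) and so leaves no step that can be told apart from the usual scatter, while the same kind of swap on the core of compound 1 gives a 19-fold higher number from compound 1 to compound 2 (1.27 log units; beyond the scatter) and stands well clear of it. This shows that the large step did not carry over: the size of a methyl step on one core could not be taken as a guide to its size on the other, in these two pairs at least. It does not show which difference between the pairs matters, since they differ both in the core and in where the methyl sits, here ortho to a large group and para to a 1,3-benzoxazol-2-yl group, and nothing available bears on why the two steps differ.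

The compounds shown leave open whether a methyl on another carbon of that ring in compound 3 would give a step beyond the scatter. They also leave open how a longer chain such as ethyl, an amine or a carboxylic acid at the same carbon would read in this assay against compound 3.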